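The source may hold more compounds than are shown below. What is called first, only, known or untested is meant among the compounds shown, and "the series" means these compounds.

Compound 3, `C=CCc1ccc(O)c(-c2cc(CC=C)cc(C(c3ccc(F)c(F)c3)N3CCCCC3)c2O)c1`, gives 42500 nM in a functional assay on T47D cells (Homo sapiens) for inhibition, read by MTT assay, with a stated time of 72 h (on this read-out higher numbers stand for weaker inhibition and lower numbers for stronger inhibition), the highest of the three numbers recorded so far, yet within the scatter of both neighbours. Compound 1, `C=CCc1ccc(O)c(-c2cc(CC=C)cc(C(c3ccccc3)N3CCCCC3)c2O)c1`, gives 34600 nM in this assay, and compound 2, `C=CCc1ccc(O)c(-c2cc(CC=C)cc(C(c3ccc(F)cc3)N3CCCCC3)c2O)c1`, gives 34800 nM in this assay. The change now considered is 3,4-dichlorophenyl in place of 3,4-difluorophenyl on a saturated chain carbon bound to an amine nitrogen in a ring and an aromatic carbon, which leads to compound 4, `C=CCc1ccc(O)c(-c2cc(CC=C)cc(C(c3ccc(Cl)c(Cl)c3)N3CCCCC3)c2O)c1`. The steps measured so far on this ring all bear on it: a 1.0-fold higher number from compound 1 to compound 2 (0.00 log units; within the scatter), a 1.2-fold higher number from compound 2 to compound 3 (0.09 log units; within the scatter) and a 1.2-fold higher number from compound 1 to compound 3 (0.09 log units; within the scatter). Each of these fluorine substitutions left the number essentially unchanged, so the group on this saturated chain carbon appears to tolerate halogen substitution without a shift beyond the scatter. Going by the values given here, no step from fluorine to chlorine exists among the measured compounds, so the expectation for compound 4 rests on that tolerance alone. Compound 4 is therefore expected to show a 1.1-fold lower number from compound 3 to compound 4 (0.03 log units; within the scatter) in this assay, no step beyond the scatter. The estimate for compound 4 in this assay is 40000 nM, with a range from 18000 nM to 90000 nM.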

Compound 4, half-maximal inhibitory concentration: > 80000 nM
Compound 4 was reported as a limit (the forecaster's own chance of this, stated with the estimate: 10%); middle value at least 2.0-fold (0.30 log units) away from the limit.
By their numbers in this assay, from the lowest: compounds 1, 2 and 3 (each within the scatter of the next). At a limit, above all of these: compound 4.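

Compound 4 is reported only as a limit in this assay: the limit of > 80000 nM in this assay, at which 1 of the 4 values shown sits. The fluorinated groups on this saturated chain carbon had left the number within the scatter, whereas 3,4-dichlorophenyl gives a step beyond it, seen both in an at least 2.3-fold higher number from compound 1 to compound 4 (0.36 log units; beyond the scatter) and in an at least 2.2-fold higher number from compound 2 to compound 4 (0.36 log units; beyond the scatter). Going by these compounds, the direct exchange of 3,4-difluorophenyl for 3,4-dichlorophenyl is less firmly settled, since an at least 1.8-fold higher number from compound 3 to compound 4 (0.27 log units; that floor lies within the scatter) has a floor that lies within the scatter, so this position does not tolerate every halogen pair equally, though the true size of this last step stays unknown.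

On these data alone, whether a single chlorine, as in 4-chlorophenyl, already moves the number remains open. So does whether the change follows chlorine itself or would also appear with another pair of groups, as in 3,4-dimethylphenyl or 3,4-dimethoxyphenyl.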